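Bromo for chloro on the sulfonamide aryl: the next step

A few compounds are considered here, and "the series" means these few. Any claim that something is new, unique, unknown or untested is made for them only; others in the source may bear on it.

Measured so far:
compound 1, `CC(C)C(NS(=O)(=O)c1ccc(Cl)cc1)C1=CC(=O)c2c(O)ccc(O)c2C1=O`: 8650 nM
compound 2, `CC(C)C(NS(=O)(=O)c1ccc(Br)cc1)C1=CC(=O)c2c(O)ccc(O)c2C1=O`: 7650 nM
compound 3, `CC(NS(=O)(=O)c1ccc(Cl)cc1)C1=CC(=O)c2c(O)ccc(O)c2C1=O`: 810 nM

In a functional assay on HeLa cells (Homo sapiens) for cytotoxicity, read by sulforhodamine B assay (on this read-out higher numbers stand for weaker inhibition and lower numbers for stronger inhibition), compound 1 gives 8650 nM and compound 2 gives 7650 nM. The two differ by bromo in place of chloro on an aromatic carbon, and the step, a 1.1-fold lower number from compound 1 to compound 2 (0.05 log units; within the scatter), is within the scatter. Compound 3 gives 810 nM in this assay; it differs from compound 1 by methyl in place of isopropyl on a saturated chain carbon bound to a double-bonded ring carbon and a sulfonamide nitrogen, and that step, an 11-fold lower number from compound 1 to compound 3 (1.03 log units; beyond the scatter), is large. Compound 3 has the lowest number of the three measured compounds.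

Compound 4, `CC(NS(=O)(=O)c1ccc(Br)cc1)C1=CC(=O)c2c(O)ccc(O)c2C1=O`, has not yet been measured in this assay. Among the measured compounds shown here, it differs from compound 3 by bromo in place of chloro on an aromatic carbon, which is the same change as the one from compound 1 to compound 2, at the same place. The two cores differ by methyl in place of isopropyl on a saturated chain carbon bound to a double-bonded ring carbon and a sulfonamide nitrogen, as noted. Because compound 1 to compound 2 gave a 1.1-fold lower number from compound 1 to compound 2 (0.05 log units; within the scatter), a step within the scatter, the step is expected to be small here as well: a 1.1-fold lower number from compound 3 to compound 4 (0.03 log units; within the scatter). This expectation rests on a single earlier instance of the change, so its direction is not fixed by the data. Compound 4 is therefore expected to give about 750 nM in this assay, most likely between 400 nM and 1400 nM.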

Compound 4, half-maximal inhibitory concentration: 5210 nM
Compound 4: middle estimate off by 6.9-fold (0.84 log units), on the low side, and the stated range ends below it.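

In this assay, bromo in place of chloro on the methyl-bearing core gives a 6.4-fold higher number from compound 3 to compound 4 (0.81 log units; beyond the scatter), so the near-silent result of this change on the isopropyl-bearing core does not carry over to the methyl-bearing core: the same change on two cores in this assay, a 1.1-fold lower number (0.05 log units; within the scatter) from compound 1 to compound 2 and a 6.4-fold higher number (0.81 log units; beyond the scatter) from compound 3 to compound 4, 7.3-fold (0.86 log units) apart, beyond the scatter of two such steps

Read along the other edge of the same set, methyl in place of isopropyl gives a 1.5-fold lower number from compound 2 to compound 4 (0.17 log units; within the scatter) with bromo on the aryl ring, so the large step seen with chloro does not reappear with bromo: the same change on two cores in this assay, an 11-fold lower number (1.03 log units; beyond the scatter) from compound 1 to compound 3 and a 1.5-fold lower number (0.17 log units; within the scatter) from compound 2 to compound 4, 7.3-fold (0.86 log units) apart, beyond the scatter of two such steps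

These four compounds show that, in this set, the result of a change at one place depends on the group at the other, but they do not show the cause of that dependence, nor whether it extends to any compound beyond these four.

Still open, going by these compounds, is whether the low number of compound 3 is particular to chloro or would also appear with fluoro, methyl or methoxy in place of the halogen on the aryl ring. Equally open, on these data alone, is how an unbranched ethyl or a longer chain in place of methyl or isopropyl would behave with chloro and with bromo on the aryl ring.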